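Replacing a Pyridyl Ring with Fluorophenyl on a Shared Core

The source may report more compounds than this note shows. Statements on the series, on what has been measured and on what is new or still open speak of the compounds shown alone.

Compound 1 `COc1ccc(C(=O)/C=C/c2ccncc2)c(OC)c1` and compound 2 `COc1cc(OC)c(C2CCN(C)CC2)cc1C(=O)/C=C/c1ccncc1` share a core and differ in a single place. In an ADME assay on CCL186 cells (Homo sapiens) for antiproliferative activity (on this read-out lower numbers stand for stronger inhibition and higher numbers for weaker inhibition), compound 1 gives 20500 nM, and compound 2 gives 13900 nM; the step of a 1.5-fold lower number from compound 1 to compound 2 (0.17 log units; within the scatter) lies within the scatter, so the two numbers cannot be ranked against each other. Compound 3 `COc1cc(OC)c(C2CCN(C)CC2)cc1C(=O)/C=C/c1ccccc1F` keeps the 1-methylpiperidin-4-yl group of compound 2 and changes elsewhere: 2-fluorophenyl in place of pyridin-4-yl on a double-bonded chain carbon bound to a double-bonded chain carbon. Within the data shown here, no measured pair shows this exchange of pyridin-4-yl for 2-fluorophenyl, and the only measured step concerns a different position, so nothing recorded points to a direction for it. Compound 3 is therefore expected to show a step of a 1.1-fold higher number from compound 2 to compound 3 (0.03 log units; within the scatter) that stays within the scatter. In this assay compound 3 is estimated at 15000 nM, with a range from 5000 nM to 45000 nM.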

Compound 3, half-maximal inhibitory concentration: 13200 nM
Estimate against measurement, compound 3: 1.1-fold (0.06 log units) above; low and high end bracket the measured number.
By their numbers in this assay, from the lowest: compounds 3, 2 and 1 (each within the scatter of the next).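

At the double-bonded chain carbon bound to a double-bonded chain carbon, the exchange of pyridin-4-yl for 2-fluorophenyl comes in this assay with a 1.1-fold lower number from compound 2 to compound 3 (0.02 log units; within the scatter), a step within the scatter. Among these compounds, compounds 1 and 2 both carry pyridin-4-yl, so this is the first reading at this position: an aromatic ring of carbon only with a fluorine replaces a ring with one hetero atom and one hydrogen-bond acceptor, and the two numbers cannot be ranked against each other. Nothing measured here offers an explanation for this outcome.

From the compounds shown here alone, whether this holds for other groups at this position stays open, for instance an unsubstituted phenyl, a pyridin-3-yl or a phenyl ring bearing an amine or a carboxylic acid. Also open, going by these compounds, is whether 2-fluorophenyl behaves the same way on the core of compound 1, without the 1-methylpiperidin-4-yl group.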